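The compounds below may be only part of what the source reports. "The series", "measured", "known", "first", "only" and "open" are said of these compounds alone.

Measured compounds in a functional assay on MIA PaCa-2 cells (Homo sapiens) for inhibition, read by MTT assay, with a stated time of 7 days; on this read-out higher numbers stand for weaker inhibition and lower numbers for stronger inhibition:
compound 1, `O=C([C@@H]1CCCN(S(=O)(=O)c2ccc(S(=O)(=O)C3CCC3)cc2)C1)N1CCC(F)(F)CC1`, 9 nM
compound 2, `CCN(CC)S(=O)(=O)c1ccc(S(=O)(=O)N2CCC[C@@H](C(=O)N3CCOCC3)C2)cc1`, 350 nM
compound 3, `O=C([C@@H]1CCCN(S(=O)(=O)c2ccc(S(=O)(=O)C3CC3)cc2)C1)N1CCC(F)(F)CC1`, 26 nM

Compound 2 stands highest of the three numbers in this assay; compound 3 gives a lower number and compound 1 the lowest, both beyond the scatter. Compound 4, `CCN(CC)S(=O)(=O)c1ccc(S(=O)(=O)N2CCC[C@@H](C(=O)N3CCS(=O)(=O)CC3)C2)cc1`, differs from compound 2 by 1,1-dioxothiomorpholin-4-yl in place of morpholin-4-yl on a carbonyl carbon. Among the compounds with values here, the one measured step, a 2.9-fold higher number from compound 1 to compound 3 (0.46 log units; beyond the scatter), concerns the group on the sulfonyl sulfur and not the amide ring, so no measured step bears on this change. Nothing in the series shows a change at the amide ring, so no step beyond the scatter is expected from compound 2 to compound 4. Compound 4 is therefore estimated at 350 nM, with a range of 120 nM to 1000 nM, meaning no change at the digits printed from compound 2 to compound 4 (within the scatter).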

Compound 4, half-maximal inhibitory concentration: 900 nM
The estimate for compound 4 lay 2.6-fold (0.41 log units) below the measured number, within the range that was stated.
By their numbers in this assay, from the lowest: compound 1; then compound 3; then compound 2; then compound 4.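

In this assay, the group on this carbonyl carbon is not neutral to the potency read-out: the change to 1,1-dioxothiomorpholin-4-yl gives a 2.6-fold higher number from compound 2 to compound 4 (0.41 log units; beyond the scatter), a modest weakening. Within the data shown here, this is the first measured step at the amide ring, and it shows that the morpholin-4-yl ring is the better of these two on this core. Nothing available explains the step.

From the compounds shown here alone, whether the loss follows the ring sulfur or its two oxygens stays open, and thiomorpholin-4-yl or piperazin-1-yl would test this. Going by these compounds, whether the step carries over to the core of compound 1 is also open.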